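This account rests on a few compounds, and the source may have more. Where it says the series, first, only, none or still open, it means among the compounds named here.

Compound 1 `Cc1ccc(C2=NN(c3nc(-c4ccc(Cl)cc4)cs3)C(c3ccc(F)cc3)C2)s1` gives > 500 ug/mL in an ADME assay on NIH3T3 cells (Mus musculus) for cytotoxicity, read by XTT assay, with a stated time of 24 h (a lower number here means a stronger inhibitor, a higher number a weaker inhibitor), which is a limit of the assay rather than a number.
Compound 2 `Cc1ccc(C2=NN(c3nc(-c4ccc([N+](=O)[O-])cc4)cs3)C(c3ccc(F)cc3)C2)s1` gives 15.6 ug/mL in this assay.
Compound 3 `Cc1ccc(C2=NN(c3nc(-c4ccc(Br)cc4)cs3)C(c3ccc(F)cc3)C2)s1` gives > 500 ug/mL in this assay, again only a limit.

Compound 3 therefore sits at the limit of > 500 ug/mL in this assay, at which 2 of the 3 values shown sit, and no exact number is known for it. Compound 4 `Cc1ccc(C2=NN(c3nc(-c4ccc(C(F)(F)F)cc4)cs3)C(c3ccc(F)cc3)C2)s1` differs from compound 3 by trifluoromethyl in place of bromo on an aromatic carbon. Going by the values given here, two measured steps bear on this position: an at least 32-fold lower number from compound 1 to compound 2 (1.50 log units; beyond the scatter) and an at least 32-fold higher number from compound 2 to compound 3 (1.50 log units; beyond the scatter), both large, whereas a step that the two limits leave unreadable from compound 1 to compound 3. Chloro and bromo both leave the value at the limit; only nitro gives a readable number. Trifluoromethyl has no measured step of its own here, so no change beyond the scatter is expected, the expected step being a number no higher from compound 3 to compound 4 (the limit leaves the size open). Compound 4 is thus estimated at about 500 ug/mL in this assay, within 120 ug/mL to 1000 ug/mL.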

Compound 4, half-maximal inhibitory concentration: > 500 ug/mL
Compound 4 gave a limit, no number (the forecaster's own chance of this, stated with the estimate: 60%); the middle value sits exactly at the limit.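

In this assay compound 4 also gives only a limit, so trifluoromethyl joins chloro and bromo, and the steps among compound 1, compound 3 and compound 4 cannot be read. Nitro remains the only group at this position with a readable number, and trifluoromethyl in its place gives an at least 32-fold higher number from compound 2 to compound 4 (1.50 log units; beyond the scatter). Compound 2 now stands alone against the other three: the limit of > 500 ug/mL in this assay, at which 3 of the 4 values shown sit.

Going by these compounds, the true values of compound 1, compound 3 and compound 4 remain unknown. Also open, on these data alone, is whether an amine or a carboxylic acid at this position would give a readable number.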